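The compounds below may be only part of what the source reports. "The series", "measured", "known", "first", "only" and "open" are said of these compounds alone.

Compound 2 `COc1cc(Oc2cccc(Nc3ccccc3)c2)cc(OC)c1CNCc1ccc(C)cc1` is the weaker of the two compounds that give a number in a functional assay on HCT-116 cells (Homo sapiens) for inhibition, read by MTT assay, with a stated time of 72 h; a higher number here means a weaker inhibitor, a lower number a stronger inhibitor: compound 2 gives 13800 nM, while compound 1 `COc1ccc(CCCNCc2c(OC)cc(Oc3ccc(Nc4ccccc4)cc3)cc2OC)cc1`, which differs from it in several places, gives 3230 nM in this assay, a gap beyond the usual scatter. Compound 3 `COc1cc(Oc2cccc(Nc3ccccc3)c2)cc(OC)c1CNC1CC1` gives only a limit in this assay, > 20000 nM, so the step of an at least 1.4-fold higher number from compound 2 to compound 3 (0.16 log units; that floor lies within the scatter) can only be read as a floor (the limit of > 20000 nM in this assay, at which 1 of the 3 values shown sits).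

Compound 4 `COc1cc(Oc2cccc(Nc3ccccc3)c2)cc(OC)c1CNCc1ccc(O)cc1` differs from compound 2 by hydroxy in place of methyl on an aromatic carbon. Within the data shown here, the one measured step that touches the same amine nitrogen, an at least 1.4-fold higher number from compound 2 to compound 3 (0.16 log units; that floor lies within the scatter), concerns cyclopropyl in place of 4-methylbenzyl, a different change, and its size is only a floor within the scatter. Among the measured compounds shown here, no measured step shows hydroxy in place of methyl on an aromatic carbon. Compound 4 is therefore expected to stay close to compound 2, with a step of a 1.2-fold lower number from compound 2 to compound 4 (0.06 log units; within the scatter) that is not expected to reach beyond the scatter. Compound 4 is estimated at 12000 nM in this assay, within a range of 4000 nM to 40000 nM.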

Compound 4, half-maximal inhibitory concentration: 3360 nM
For compound 4 the middle estimate is 3.6-fold (0.55 log units) above the measured one; measured number below the stated range.
By their numbers in this assay, from the lowest: compounds 1 and 4 (each within the scatter of the next); then compound 2. At a limit, above all of these: compound 3.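

On the 4-methylbenzyl group of compound 2, the para position is not a silent one: exchanging a single heavy atom, hydroxy in place of methyl on an aromatic carbon, gives a 4.1-fold lower number from compound 2 to compound 4 (0.61 log units; beyond the scatter) in this assay. This is the first step in the compounds shown that can be read as a full number and lies beyond the scatter, and it comes from a change far smaller than replacing the whole group on the amine nitrogen. With 4-hydroxybenzyl in place of cyclopropyl on that nitrogen the result is an at least 5.9-fold lower number from compound 3 to compound 4 (0.77 log units; beyond the scatter), but this is only a floor: the limit of > 20000 nM in this assay, at which 1 of the 4 values shown sits.

As far as these compounds go, whether a methoxy, an amine or a carboxylic acid in the same place would give a step of like size stays open. So does whether hydroxy would have the same effect on the longer chain of compound 1.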